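Difluoroethyl in place of hydrogen: compound 2 to compound 4

The source may report more compounds than this note shows. Statements on the series, on what has been measured and on what is new or still open speak of the compounds shown alone.

Among the compounds with values here, compound 2 `CNc1cc(Oc2ccc(NC(=O)Nc3ccccc3)cc2)ncn1` gives 6300 nM in an assay on isolated protein for inhibition of serine/threonine-protein kinase TNNI3K (Homo sapiens) (on this read-out lower numbers stand for stronger inhibition and higher numbers for weaker inhibition), the highest of the three numbers measured so far. Its nearest neighbour is compound 1 `CNc1cc(Oc2ccc(NC(=O)Nc3cccc(C(F)F)c3)cc2)ncn1`, which gives 100 nM; compound 3 `CCCNc1cc(Oc2ccc(NC(=O)Nc3cccc(C(F)(F)F)c3)cc2)ncn1` gives 32 nM. Compound 4 `CNc1cc(Oc2ccc(NC(=O)Nc3cccc(C(C)(F)F)c3)cc2)ncn1` differs from compound 2 by 1,1-difluoroethyl in place of hydrogen on an aromatic carbon. Within the data shown here, the one measured step that bears on this change is a 63-fold higher number from compound 1 to compound 2 (1.80 log units; beyond the scatter), where a difluoromethyl group was removed; the new change runs the other way with a closely related group. Among the measured compounds shown here, compound 3 carries a trifluoromethyl group and a propyl chain on the amine instead of a methyl, so its value shows only that both changes together give a low number. Compound 4 is therefore expected to take a large step down, a 63-fold lower number from compound 2 to compound 4 (1.80 log units; beyond the scatter), estimated at 100 nM with a range of 30 nM to 400 nM.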

Compound 4, half-maximal inhibitory concentration: 40 nM
Estimate against measurement, compound 4: 2.5-fold (0.40 log units) above, within the range that was stated.
By their numbers in this assay, from the lowest: compounds 3 and 4 (each within the scatter of the next); then compound 1; then compound 2.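

In this assay, within the data shown here, 1,1-difluoroethyl on this aromatic carbon gives a 160-fold lower number from compound 2 to compound 4 (2.20 log units; beyond the scatter) and so shows that difluoromethyl is not the only fluorinated group that brings a large step here. Methyl in place of hydrogen on the carbon bearing the two fluorine atoms gives a 2.5-fold lower number from compound 1 to compound 4 (0.40 log units; beyond the scatter) as a further modest step, so the number at this position still responds to a change on that carbon. Nothing at hand bears on the cause of either step.

Going by these compounds, what a plain ethyl group at this place would give without the fluorine atoms stays open. So does the effect of the propyl chain on the amine taken alone.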